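Swapping 4-methylpiperazin-1-yl for 4-methylpiperidin-1-yl

The source may hold more compounds than are shown below. What is called first, only, known or untested is meant among the compounds shown, and "the series" means these compounds.

In a functional assay on RAW264.7 cells (Mus musculus) for inhibition, read by MTT assay, with a stated time of 72 h (a lower number here means a stronger inhibitor, a higher number a weaker inhibitor), compound 1 `CCc1nc2c(C)cc(-c3ccc(CN4CCC[C@H]4CO)cc3)cn2c1NC(=O)OCc1cc(Cl)cc(Cl)c1` gives 2510 nM and compound 2 `CCc1nc2c(C)cc(-c3ccc(CN4CCN(C)CC4)cc3)cn2c1NC(=O)OCc1cc(Cl)cc(Cl)c1` gives 1410 nM as its reading. These two numbers lie within the scatter of each other, so compound 2 stands level with compound 1 and no ranking can be drawn between them.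

Compound 3 `CCc1nc2c(C)cc(-c3ccc(CN4CCC(C)CC4)cc3)cn2c1NC(=O)OCc1cc(Cl)cc(Cl)c1` has not yet been measured. It differs from compound 2 by 4-methylpiperidin-1-yl in place of 4-methylpiperazin-1-yl on a saturated chain carbon bound to an aromatic carbon with 4-methylpiperidin-1-yl in place of 4-methylpiperazin-1-yl on a saturated chain carbon bound to an aromatic carbon.

For the measured compounds named here, only one measured step bears on this place: a 1.8-fold lower number from compound 1 to compound 2 (0.25 log units; within the scatter) for a different exchange, 4-methylpiperazin-1-yl in place of 2-(hydroxymethyl)pyrrolidin-1-yl. Going by the values given here, no measured compound carries 4-methylpiperidin-1-yl, so this small step is an indirect guide. On that basis no change beyond the scatter is expected in this assay for the new exchange, in either direction. The estimate is a 1.1-fold lower number from compound 2 to compound 3 (0.04 log units; within the scatter) and amounts to no real shift. Compound 3 is expected at 1300 nM with 550 nM to 3000 nM as its estimated range.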

Compound 3, half-maximal inhibitory concentration: 2130 nM
For compound 3 the middle estimate is 1.6-fold (0.21 log units) below the measured one, within the range that was stated.
By their numbers in this assay, from the lowest: compounds 2, 3 and 1 (each within the scatter of the next).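

In this assay, on a saturated chain carbon bound to an aromatic carbon, 4-methylpiperidin-1-yl in place of 4-methylpiperazin-1-yl keeps 7 heavy atoms but takes the six-membered ring from 2 hetero atoms to 1 hetero atom and gives a 1.5-fold higher number from compound 2 to compound 3 (0.18 log units; within the scatter) at this place, so removing that ring nitrogen leaves the reading level with that of compound 2. The exchange of 2-(hydroxymethyl)pyrrolidin-1-yl for the same group gives a 1.2-fold lower number from compound 1 to compound 3 (0.07 log units; within the scatter) and so adds a third group that stands level with the others, which means that compounds 1, 2 and 3 show no ranking among the groups at this position. No independent measurement is at hand that would help explain these readings.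

On these data alone, what remains open is whether any group at this place can move the number beyond the scatter, for example morpholin-4-yl, an open-chain dimethylamino group or a carboxylic acid. As far as these compounds go, it is equally open whether a longer chain between the aromatic carbon and the ring would leave the readings as level as these three are.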